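The compounds below may be only part of what the source reports. "The series", "measured", "known", "first", "only" and "open" are said of these compounds alone.

Within the data shown here, compound 1 `O=Cc1ccc(-c2cnc(C(=O)CCCCCCc3ccccc3)o2)nc1` stands lowest of the two numbers so far: in an assay for inhibition of Fatty-acid amide hydrolase 1 (Rattus norvegicus), using a Dixon plot (a lower number here means a stronger inhibitor, a higher number a weaker inhibitor), compound 1 gives 2.2 nM, while compound 2 `C[S+]([O-])/C=C/c1ccc(-c2cnc(C(=O)CCCCCCc3ccccc3)o2)nc1` gives 3 nM, a step of a 1.4-fold higher number from compound 1 to compound 2 (0.13 log units; within the scatter). Compound 3 `O=CCCCCc1cnc(C(=O)CCCCCCc2ccccc2)o1` differs from compound 1 by a group of 6 heavy atoms (5 carbon, 1 oxygen; no ring) in place of a group of 8 heavy atoms (6 carbon, 1 nitrogen, 1 oxygen; one six-membered aromatic ring with 1 hetero atom), on an aromatic carbon. Among the measured compounds shown here, the only measured step alters a group carried on the six-membered ring that here leaves entirely, so it bears on this change only loosely and was itself within the scatter. Removing that ring is a larger change, and a weaker inhibitor is expected, by roughly a 4.5-fold higher number from compound 1 to compound 3 (0.66 log units; beyond the scatter). Compound 3 is therefore estimated at 10 nM, between 3 nM and 40 nM.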

Compound 3, inhibition constant: 14.6 nM
Beside the measured number, compound 3's estimate is 1.5-fold (0.16 log units) below it, and the stated range covers the measured number.
By their numbers in this assay, from the lowest: compounds 1 and 2 (each within the scatter of the next); then compound 3.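

Among these compounds, at the aromatic carbon next to the ring oxygen, putting 4-formylbutyl in place of the six-membered aromatic ring and its formyl group gives a 6.6-fold higher number from compound 1 to compound 3 (0.82 log units; beyond the scatter) in this assay and is the first step here beyond the scatter. Even so, compound 3 gives 14.6 nM with no ring at this place, so the ring is not needed for a nanomolar number. Nothing available accounts for the loss. The compounds shown leave open whether a carboxylic acid or an amine at the chain end would do better than the formyl group, and how a shorter or longer chain would compare.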